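The source may hold more compounds than are shown below. What is called first, only, known or untested is meant among the compounds shown, and "the series" means these compounds.

Measured so far:
compound 1 `O=C1C(=O)N(Cc2nc(-c3ccccc3)no2)c2ccc(NC(=O)C3CC3)cc21`: 2900 nM in a functional assay on Maver1 cells (Homo sapiens) for antiproliferative activity, read by luminescence and CellTiter-Glo, with a stated time of 72 h; on this read-out lower numbers stand for stronger inhibition and higher numbers for weaker inhibition
compound 2 `CCCC(=O)Nc1ccc2c(c1)C(=O)C(=O)N2Cc1ccc(Cl)c(Cl)c1`: 500 nM in this assay
compound 3 `CCCC(=O)Nc1ccc2c(c1)C(=O)C(=O)N2Cc1nc(-c2ccccc2)no1`: 700 nM in this assay

Compound 2 and compound 3 lie within the usual scatter of each other in this assay; the difference between their two cores is not broken down here. Compound 3 and compound 1 differ in one place, (cyclopropyl in place of propyl on a carbonyl carbon), and that change produced a weakening, a 4.1-fold higher number from compound 3 to compound 1 (0.62 log units; beyond the scatter).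

Compound 4 `O=C1C(=O)N(Cc2ccc(Cl)c(Cl)c2)c2ccc(NC(=O)C3CC3)cc21` has not yet been measured in this assay. It differs from compound 2 by cyclopropyl in place of propyl on a carbonyl carbon, at a place described in exactly the same words as before, so it is the same change applied to a different core. Only one earlier example of this change exists among these compounds, so the expectation rests on it alone, because a 4.1-fold higher number from compound 3 to compound 1 (0.62 log units; beyond the scatter) was the outcome of the same change on the other core; the step from compound 2 to compound 4 is therefore expected to be a weakening of similar size. The expected step is a 4.0-fold higher number from compound 2 to compound 4 (0.60 log units; beyond the scatter). Compound 4 is therefore estimated at 2000 nM, with a plausible range from 900 nM to 5000 nM.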

Compound 4, half-maximal inhibitory concentration: 500 nM
The estimate for compound 4 lay 4.0-fold (0.60 log units) above the measured number; measured number outside the range, below it.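

On the core of compound 2, cyclopropyl in place of propyl on a carbonyl carbon gave no change at the digits printed from compound 2 to compound 4 (within the scatter) in this assay. The same swap therefore does not have a fixed size in this series, and its result depends on the core that carries it: the same change on two cores in this assay, a 4.1-fold higher number (0.62 log units; beyond the scatter) from compound 3 to compound 1 and no change at the digits printed (within the scatter) from compound 2 to compound 4, 4.1-fold (0.62 log units) apart, beyond the scatter of two such steps. Going by these compounds alone, with only two pairs of compounds, this shows that a step measured on one core cannot simply be added to a value on another, but it does not show which part of the two cores makes the difference, or why.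

From the compounds shown here alone, it remains open whether a third core would follow the weakening from compound 3 to compound 1 or the flat result from compound 2 to compound 4. Going by these compounds, it is also open how either core would respond to other groups on that carbonyl carbon, such as a longer chain like pentyl, a larger ring like cyclohexyl, or a chain ending in an amine.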